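The source may hold more compounds than are shown below. What is called first, only, known or untested is meant among the compounds shown, and "the series" means these compounds.

Measured so far:
compound 1, `CN1CCN(c2ccc(Nc3nc(-c4cccc(NC(=O)c5ccccc5F)c4)sc3C(N)=O)cc2)CC1` — 1360 nM
compound 2, `CN1CCN(c2ccc(Nc3nc(-c4cccc(NC(=O)c5ccc(C(F)(F)F)cn5)c4)sc3C(N)=O)cc2)CC1` — 19800 nM

Of these two numbers, compound 2 has the higher one: in a functional assay on Ramos cells (Homo sapiens) for antiproliferative activity, read by CCK-8 assay, with a stated time of 72 h (a higher number here means a weaker inhibitor, a lower number a stronger inhibitor), compound 2 gives 19800 nM, while compound 1 gives 1360 nM, a gap beyond the scatter. Compound 3, `CN1CCN(c2ccc(Nc3nc(-c4cccc(NC(=O)c5ccco5)c4)sc3C(N)=O)cc2)CC1`, has not been measured. It differs from compound 2 in one place: furan-2-yl in place of 5-(trifluoromethyl)pyridin-2-yl on a carbonyl carbon. Among the measured compounds shown here, only one measured step bears on this position, a 15-fold higher number from compound 1 to compound 2 (1.16 log units; beyond the scatter), which shows that the number at this amide position can move a long way when the aromatic group on the carbonyl carbon is exchanged. Moving from compound 2 to compound 3 again exchanges that group, and since the step to compound 2 was upward, the expectation is a step back downward, a 6.6-fold lower number from compound 2 to compound 3 (0.82 log units; beyond the scatter), though its size is uncertain with a single step as guide. For compound 3 the estimated value in this assay is 3000 nM, with a range from 800 nM to 12000 nM.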

Compound 3, half-maximal inhibitory concentration: 19700 nM
Estimate against measurement, compound 3: 6.6-fold (0.82 log units) below; the whole stated range lies below it.
By their numbers in this assay, from the lowest: compound 1; then compounds 3 and 2 (each within the scatter of the next).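

In this assay, exchanging the group on the carbonyl carbon gives a 1.0-fold lower number from compound 2 to compound 3 (0.00 log units; within the scatter), so furan-2-yl and 5-(trifluoromethyl)pyridin-2-yl cannot be told apart here, even though one is a five-membered ring and the other a larger six-membered ring carrying trifluoromethyl. The 2-fluorophenyl group now stands apart from both: furan-2-yl in its place gives a 14-fold higher number from compound 1 to compound 3 (1.16 log units; beyond the scatter), which shows that the large rise seen earlier is not peculiar to 5-(trifluoromethyl)pyridin-2-yl. Nothing measured here offers a reason for this pattern.

The compounds shown leave open whether the lower number of compound 1 depends on its fluorine or only on the phenyl group, which an unsubstituted phenyl group would test. They also leave open how a non-aromatic group on the carbonyl carbon, such as a cyclohexyl ring or a short alkyl chain, would compare.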